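From Tert-Butyl to a Hexyl Chain

A few compounds are considered here, and "the series" means these few. Any claim that something is new, unique, unknown or untested is made for them only; others in the source may bear on it.

In a functional assay on brain (Rattus norvegicus, strain Wistar) for inhibition (a higher number here means a weaker inhibitor, a lower number a stronger inhibitor), compound 3 (`Cc1[nH]c(=O)n(C)c1-c1ccc(C(C)(C)C)cc1`) gives 8400 nM as its half-maximal inhibitory concentration. That is within the usual scatter of compound 1 (`CCCCOc1ccc(-c2c(C)[nH]c(=O)n2C)cc1`), which gives 5100 nM on the same read-out. Compound 2 (`Cc1ccc(-c2c(C)[nH]c(=O)n2C)cc1`) gives 85300 nM and is the weakest of the three.

Compound 4 (`CCCCCCc1ccc(-c2c(C)[nH]c(=O)n2C)cc1`) carries a single change (hexyl in place of tert-butyl on an aromatic carbon), with hexyl in place of tert-butyl on an aromatic carbon. Three measured steps at this same place bear on it. Tert-butyl in place of methyl gave a 10-fold lower number from compound 2 to compound 3 (1.01 log units; beyond the scatter) and methyl in place of butoxy gave a 17-fold higher number from compound 1 to compound 2 (1.22 log units; beyond the scatter) and both of these were large. Tert-butyl in place of butoxy gave a 1.6-fold higher number from compound 1 to compound 3 (0.22 log units; within the scatter) and so did not move the number beyond the scatter. Methyl is the one group of the three that stands apart, but no compound with a hexyl chain has been measured yet. Compound 4 is therefore expected to resemble compound 1 and compound 3 rather than compound 2. A small shift toward a lower number is expected, and the estimated change is a 1.9-fold lower number from compound 3 to compound 4 (0.27 log units; within the scatter) in this assay and no larger. The estimate for compound 4 is 4500 nM with an expected range of 1500 nM to 13000 nM until a measurement is available.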

Compound 4, half-maximal inhibitory concentration: 9000 nM
For compound 4 the middle estimate is 2.0-fold (0.30 log units) below the measured one; the range from low to high includes it.
By their numbers in this assay, from the lowest: compounds 1, 3 and 4 (each within the scatter of the next); then compound 2.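

In this assay the swap of tert-butyl for hexyl gives a 1.1-fold higher number from compound 3 to compound 4 (0.03 log units; within the scatter) and the swap of butoxy for hexyl gives a 1.8-fold higher number from compound 1 to compound 4 (0.25 log units; within the scatter) so at this place on the aromatic ring a chain of 6 heavy atoms cannot be told apart from either of the two larger groups already seen, even though tert-butyl has only 4 heavy atoms. Against the small methyl group of compound 2 the picture is different, with a 9.5-fold lower number from compound 2 to compound 4 (0.98 log units; beyond the scatter) so compound 4 joins compound 1 and compound 3 as a group of three on one side of a clear gap, and going from tert-butyl to hexyl adds nothing further on top of what tert-butyl already gained over methyl. Nothing available here explains why these three groups behave alike.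

The compounds shown do not say where between methyl and the larger groups the drop in the number sets in, which an ethyl or propyl group at this place could show. They also leave open whether a longer chain such as octyl, or a hexyl chain ending in an amine or a carboxylic acid, would stay level with compound 4 or move away from it.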